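Aryl swap on the sulfonamide of compound 1

The source may hold more compounds than are shown below. What is called first, only, known or untested is meant among the compounds shown, and "the series" means these compounds.

Measured so far:
- compound 1, `N#Cc1ccc(S(=O)(=O)Nc2cccc([C@@H](c3c(O)oc4c(c3=O)CCCCCC4)C3CC3)c2)cc1`: in an in vivo ADME assay on the whole organism (Rattus norvegicus) for pharmacokinetics (on this read-out higher numbers stand for higher oral bioavailability and lower numbers for lower oral bioavailability), compound 1 gives 42%
- compound 2, `N#Cc1ccc(S(=O)(=O)Nc2cccc([C@H](c3c(O)oc4c(c3=O)CCCCCC4)C3CC3)c2)cc1`: in this assay compound 2 gives 31%

Compound 1 stands highest of the two numbers; the nearest is compound 2, reached by the step of a number 11 percentage points lower from compound 1 to compound 2 (beyond the scatter). That step rests on (the fact that compounds 1 and 2 differ only in the configuration as drawn), so it speaks only to the configuration at the saturated chain carbon and not to any change of a group.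

Compound 3, `O=c1c2c(oc(O)c1[C@H](c1cccc(NS(=O)(=O)c3cccc4cccnc34)c1)C1CC1)CCCCCC2`, is to be measured in this assay. It differs from compound 1 by quinolin-8-yl in place of 4-cyanophenyl on a sulfonyl sulfur. Within the data shown here, no measured step touches this part of the molecule: the only step at hand, from compound 1 to compound 2, is a change of configuration and offers no guide to exchanging the aryl group on the sulfonyl sulfur. The expectation therefore leans on compound 1 alone, and the step of a number 2 percentage points lower from compound 1 to compound 3 (within the scatter) is expected to stay within the scatter. For compound 3 the estimate in this assay is 40%, with a range from 20% to 60%.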

Compound 3, oral bioavailability: 34%
Beside the measured number, compound 3's estimate is 6 percentage points above it, and the stated range covers the measured number.
By their numbers in this assay, from the lowest: compounds 2, 3 and 1 (each within the scatter of the next, the first and the last beyond it).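

In this assay, among these compounds, quinolin-8-yl in place of 4-cyanophenyl on a sulfonyl sulfur gives a number 8 percentage points lower from compound 1 to compound 3 (within the scatter), the first reading on the aryl group of the sulfonamide rather than on configuration. At this position, then, a group with one six-membered aromatic ring of carbon only and a nitrile can give way to one with two six-membered aromatic rings, one holding a hetero atom, without a step in oral bioavailability that stands beyond the scatter. Among the compounds shown here, nothing at hand speaks to why the number stays within the scatter, as the only structural comparison available concerns configuration and does not touch this aryl group.

On these data alone, the result rests on a single exchange, in the configuration of compound 1, so it remains open whether quinolin-8-yl would behave the same way in the configuration of compound 2. Also open, as far as these compounds go, is how far this tolerance extends to other groups on the sulfonyl sulfur, such as an unsubstituted phenyl, a pyridin-3-yl, or a phenyl carrying a carboxylic acid or an amine.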